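This account rests on a few compounds, and the source may have more. Where it says the series, first, only, none or still open, it means among the compounds named here.

Within the data shown here, compound 1 `CN1CCN(c2nc3ccccc3n2CCO)CC1` gives 410 nM in a functional assay on ileum for inhibition of histamine H1 receptor (Cavia porcellus) (on this read-out lower numbers stand for stronger inhibition and higher numbers for weaker inhibition), the higher of the two numbers measured so far. Among the measured compounds shown here, compound 2 `CCCCN1CCCN(c2nc3ccccc3n2CCOCC)CC1` gives 8.4 nM in this assay; the two structures differ in several places, so the gap between them shows only that much lower numbers are reachable. Compound 3 `CCCC(C)n1c(N2CCN(C)CC2)nc2ccccc21` differs from compound 1 in one place: 1-methylbutyl in place of 2-hydroxyethyl on an aromatic nitrogen. For compound 3 a step beyond the scatter toward a lower number is expected, a 6.8-fold lower number from compound 1 to compound 3 (0.83 log units; beyond the scatter), guided by compound 2 with 8.4 nM. The estimate for compound 3 is 60 nM, with a range from 15 nM to 250 nM.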

Compound 3, half-maximal inhibitory concentration: 1400 nM
Beside the measured number, compound 3's estimate is 23-fold (1.37 log units) below it, outside the stated range (above it).
By their numbers in this assay, from the lowest: compound 2; then compound 1; then compound 3.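

On the aromatic nitrogen, 1-methylbutyl in place of 2-hydroxyethyl brings a 3.4-fold higher number from compound 1 to compound 3 (0.53 log units; beyond the scatter) in this assay, so this position responds to the group it carries. At this position, a larger all-carbon group does not lower the number on the core of compound 1. Nothing at hand bears on the reason for this rise. The step swaps oxygen and chain shape together, leaving their separate shares open. Also open, as far as these compounds go, is how 2-methoxyethyl or unbranched pentyl on this nitrogen would read in this assay.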